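Exchanging a Ring on the Chain Carbon of Compound 1

The compounds below may be only part of what the source reports. "The series", "measured", "known", "first", "only" and "open" are said of these compounds alone.

Compound 1, `CC(C)C(c1ccc(-c2ccc3cccc(F)c3c2)[nH]c1=O)N1CCCCS1(=O)=O`, gives 122 nM in a functional assay on CHO cells for antagonist activity at prostaglandin E2 receptor EP3 subtype (Homo sapiens), read by cAMP accumulation; a lower number here means a stronger inhibitor, a higher number a weaker inhibitor.
Compound 2, `CC(C)C(O)(C(=O)O)c1ccc(-c2ccc3ccccc3c2)[nH]c1=O`, gives 1580 nM in this assay.
Compound 3, `CCn1ncc2c(F)cc(-c3ccc(C(CC)(CC)c4nnc[nH]4)c(=O)[nH]3)cc21`, gives 29 nM in this assay.

Among these three measured numbers, compound 1 stands second highest: compound 3 sits beyond the scatter below it, and compound 2 sits beyond the scatter above it. Compound 4, `CC(C)C(c1ccc(-c2ccc3cccc(F)c3c2)[nH]c1=O)N1CCN/C1=N\C#N`, differs from compound 1 in one place: a group of 8 heavy atoms (4 carbon, 4 nitrogen; one five-membered non-aromatic ring with 2 hetero atoms) in place of a group of 8 heavy atoms (4 carbon, 1 nitrogen, 2 oxygen, 1 sulfur; one six-membered non-aromatic ring with 2 hetero atoms), on a saturated chain carbon bound to an aromatic carbon and a saturated chain carbon. Among the measured compounds shown here, no step between two measured compounds matches this exchange, so its direction is not told by the data. Compound 4 is expected to land close to compound 1, with a step of a 1.6-fold higher number from compound 1 to compound 4 (0.21 log units; within the scatter) in this assay, and its estimated value is 200 nM within a range from 50 nM to 800 nM.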

Compound 4, half-maximal inhibitory concentration: 38 nM
Beside the measured number, compound 4's estimate is 5.3-fold (0.72 log units) above it, and the stated range ends above it.
By their numbers in this assay, from the lowest: compounds 3 and 4 (each within the scatter of the next); then compound 1; then compound 2.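

At the saturated chain carbon, the five-membered non-aromatic ring with 2 hetero atoms can replace the six-membered one: in this assay the exchange gives a 3.2-fold lower number from compound 1 to compound 4 (0.51 log units; beyond the scatter) and shows that the sulfur and both oxygens of compound 1 are not needed at this position for activity. Ring size, ring atoms and the added hydrogen-bond donor all change in this one step, so the compounds do not separate their contributions. No measurement here accounts for the gain.

Open, going by these compounds, is whether a five-membered ring carrying a sulfonyl group would match compound 4, which would separate ring size from ring atoms. Also open, on these data alone, is how an open-chain urea or a simple amine would fare on the same carbon.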